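This account rests on a few compounds, and the source may have more. Where it says the series, first, only, none or still open, it means among the compounds named here.

Compound 2 `COc1ccc(Cl)cc1S(=O)(=O)Nc1ccc2oc(-c3ccccc3)nc2c1` stands at the edge of what the assay can report: in an assay on cells for inhibition of HSP60/HSP10 (Homo sapiens), with a stated time of 60 min (a lower number here means a stronger inhibitor, a higher number a weaker inhibitor), compound 2 gives > 100000 nM, which is a limit of the assay and not a number. Within the data shown here, the single measured comparison is an at least 1.3-fold higher number from compound 1 to compound 2 (0.11 log units; that floor lies within the scatter), where compound 1 `O=S(=O)(Nc1ccc2oc(-c3ccccc3)nc2c1)c1cccc(O)c1` gives 76000 nM. Compound 3 `Cc1cccc(S(=O)(=O)Nc2ccc3oc(-c4ccccc4)nc3c2)c1` has not yet been tested; it differs from compound 2 in that (3-methylphenyl in place of 5-chloro-2-methoxyphenyl on a sulfonyl sulfur). Among the measured compounds shown here, the only step that bears on this change is an at least 1.3-fold higher number from compound 1 to compound 2 (0.11 log units; that floor lies within the scatter), which was small and within the scatter, and one of its two ends rests on the assay ceiling (the limit of > 100000 nM in this assay, at which 1 of the 2 values shown sits), so the direction for compound 3 is uncertain. The expected step from compound 2 to compound 3 is therefore modest, an at least 1.1-fold lower number from compound 2 to compound 3 (0.04 log units; that floor lies within the scatter). For compound 3 the estimate is 90000 nM, expected to fall between 30000 nM and 300000 nM, with a real chance that this assay again returns only a limit.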

Compound 3, half-maximal inhibitory concentration: > 100000 nM
Compound 3 gave a limit, no number (the forecaster's own chance of this, stated with the estimate: 50%); middle value at least 1.1-fold (0.04 log units) from the limit.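

Replacing 5-chloro-2-methoxyphenyl with 3-methylphenyl on the sulfonyl sulfur does not bring a readable number back into this assay, so a simpler ring without the chlorine or the methoxy does not recover one here. Because both ends are limits, the step between compound 2 and compound 3 cannot be read: the limit of > 100000 nM in this assay, at which 2 of the 3 values shown sit.

The new readable comparison is methyl in place of hydroxy on an aromatic carbon, which gives an at least 1.3-fold higher number from compound 1 to compound 3 (0.11 log units; that floor lies within the scatter), so this floor alone does not show that the hydroxy matters.

On these data alone, how far compound 3 truly lies from compound 1 remains open, and so does the real order of compound 2 and compound 3. Also open, as far as these compounds go, is whether an amine or a carboxylic acid in place of that hydroxy would read clearly stronger than compound 1 at 76000 nM.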